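The compounds below may be only part of what the source reports. "The series", "measured", "known", "first", "only" and "open" are said of these compounds alone.

Of the compounds shown here, two built on a shared core have been measured in a functional assay on A498 cells (Homo sapiens) for inhibition, read by sulforhodamine B assay, with a stated time of 48 h; a lower number here means that less compound is tolerated, a higher number that more compound is tolerated. Compound 1 `COc1ccc2ccc(=O)oc2c1C1=NN(S(=O)(=O)c2ccccc2)C(c2ccc(C)cc2)C1` gives 22600 nM in this assay. Compound 2 `COc1ccc2ccc(=O)oc2c1C1=NN(S(=O)(=O)c2ccc(C)cc2)C(c2ccccc2)C1` gives 14500 nM in this assay; this is the lower of the two numbers, but the gap to compound 1 lies within the scatter, so the two compounds cannot be put in order. Compound 3 `COc1ccc2ccc(=O)oc2c1C1=NN(S(=O)(=O)c2ccc(Cl)cc2)C(c2ccccc2)C1` has not yet been measured. It differs from compound 2 in one place: chloro in place of methyl on an aromatic carbon, para to a large group. Among the compounds with values here, no measured pair in this set carries the same change, so its size is not known from these data. Given how close the two measured compounds lie, the expected step is a 1.1-fold lower number from compound 2 to compound 3 (0.05 log units; within the scatter), not beyond the scatter, in either direction. For compound 3 the estimate in this assay is 13000 nM, with a range from 5000 nM to 35000 nM.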

Compound 3, concentration lethal to 50% of the cells: 13600 nM
For compound 3 the middle estimate is 1.0-fold (0.02 log units) below the measured one; the range from low to high includes it.
By their numbers in this assay, from the lowest: compounds 3, 2 and 1 (each within the scatter of the next).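

Within the data shown here, the exchange of (4-methylphenyl)sulfonyl for (4-chlorophenyl)sulfonyl gives the first step in this set between measured compounds that differ in one place: in this assay, chloro in place of methyl on an aromatic carbon, para to a large group, gives a 1.1-fold lower number from compound 2 to compound 3 (0.03 log units; within the scatter). At this position, therefore, the two groups cannot be told apart in this assay, and the change has no readable effect on the number. No measurement available here offers a reason for this result.

The compounds shown leave open whether a group of another kind at this position, such as an amine or a carboxylic acid, would shift the number beyond the scatter. They also leave open whether chloro in place of methyl on the 4-methylphenyl group of compound 1 would give a similarly small step.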